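A few compounds are considered here, and "the series" means these few. Any claim that something is new, unique, unknown or untested is made for them only; others in the source may bear on it.

Measured compounds:
Compound 1, `CC(C)C/N=C(\S)NCCCCn1nc(-c2ccccc2)ccc1=O`, in a functional assay on the whole organism (stomach) with Rattus norvegicus as the target (a lower number here means that less compound is needed, a higher number that more compound is needed for the effect), gives only a limit, > 100 mg/kg.
Compound 2, `CN/C(=N/CCCCn1nc(-c2ccc(OC)cc2)ccc1=O)NC#N`, in this assay gives only a limit, > 100 mg/kg.
Compound 3, `O=c1ccc(-c2ccccc2)nn1CCCCNC(=S)Nc1ccccc1`, in this assay gives only a limit, > 100 mg/kg.

Compound 1 stands at the limit of this assay, as do the other two measured compounds, so no ranking among them is possible; all three share (the limit of > 100 mg/kg in this assay, at which 3 of the 3 values shown sit). Going by the values given here, the one single-point step among them, a step that the two limits leave unreadable from compound 1 to compound 3, is unreadable for the same reason.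

Compound 4, `C/N=C(/NC#N)NCCCCCn1nc(-c2ccccc2)ccc1=O`, differs from compound 1 by a group of 8 heavy atoms (4 carbon, 4 nitrogen; no ring) in place of a group of 8 heavy atoms (5 carbon, 2 nitrogen, 1 sulfur; no ring), on a saturated chain carbon, four bonds along the chain from an aromatic nitrogen. Among the compounds with values here, no measured step bears directly on this change. Compound 2, which carries a related entering group but on a different core, also sits at the limit. With every value at the limit, no direction or size can be read for compound 4 in this assay, and the expectation is that compound 4 again reports only a limit. Compound 4 is estimated at 150 mg/kg, within 50 mg/kg to 500 mg/kg, an expected step that the limit leaves unreadable from compound 1 to compound 4.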

Compound 4, dose for half-maximal effect: 100 mg/kg
Beside the measured number, compound 4's estimate is 1.5-fold (0.18 log units) above it; low and high end bracket the measured number.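

In this assay, going by these compounds alone, compound 4 gives 100 mg/kg, the first value that is a number and not a limit. Within the data shown here, the change on a saturated chain carbon, four bonds along the chain from an aromatic nitrogen, therefore gives the first step with a direction, a number no higher from compound 1 to compound 4 (the limit leaves the size open), although its size cannot be read. The number for compound 4 still coincides with the figure that marks the limit of the other compounds, so the series shows no clear separation from that limit: the limit of > 100 mg/kg in this assay, at which 3 of the 4 values shown sit.

On these data alone, how much lower the dose can go with a different group at this position remains open. A urea, an amine or a carboxylic acid in place of the entering group could show whether the series can move clearly away from this figure.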